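The source may hold more compounds than are shown below. What is called first, only, known or untested is meant among the compounds shown, and "the series" means these compounds.

Among the measured compounds shown here, in a functional assay on NCI-H460 cells (Homo sapiens) for inhibition, read by MTT assay, with a stated time of 24 h, tested at 1 ug/mL (a lower number here means less inhibition of growth, a higher number more inhibition of growth at the concentration tested), compound 1 (`O=C(CCCCC(S)CCS)Nc1ccc(Cl)cc1`) gives 6.76% and compound 2 (`O=C(CCCCC(S)CCS)Nc1cccc(C(F)(F)F)c1`) gives 8.26% within the scatter of each other, so compound 1 sits level with the only other number. Compound 3 (`COc1ccc(NC(=O)CCCCC(S)CCS)cc1`) has methoxy in place of chloro on an aromatic carbon, para to a large group (methoxy in place of chloro on an aromatic carbon). For the measured compounds named here, no measured pair shows such a change, so in this assay no step beyond the scatter is expected in either direction. The estimated a number 1.2 percentage points higher from compound 1 to compound 3 (within the scatter) stays within the scatter. The estimate for compound 3 is 8% with an expected range from 1% to 18% in this series.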

Compound 3, percent growth inhibition at one concentration: "not active" (no number reported)
No number was reported for compound 3; no gap can be computed for the estimate.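

Among the compounds shown here, compound 3 is reported as "not active" without a number, so no step from compound 1 to compound 3 can be read. As far as these compounds go, how far methoxy in place of chloro shifts growth inhibition stays open. Nothing shown offers an explanation for this result.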